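The source may hold more compounds than are shown below. What is called first, only, known or untested is meant among the compounds shown, and "the series" means these compounds.

Measured compounds:
- compound 1 `COc1ccc(Nc2nc3ccccc3nc2S(=O)(=O)c2ccc(C)cc2)cc1`: "not determined" (no result reported)
- compound 2 `COc1cc(Nc2nc3ccccc3nc2S(=O)(=O)c2ccc(C)cc2)cc(OC)c1`: "not determined" (no result reported)
- compound 3 `Cc1ccc(S(=O)(=O)c2nc3ccccc3nc2Nc2ccc(N)cc2)cc1`: 5630 nM

In a functional assay on KB cells (Homo sapiens) for cytotoxicity, read by MTT assay, with a stated time of 72 h (on this read-out lower numbers stand for stronger inhibition and higher numbers for weaker inhibition), compound 3 gives 5630 nM. Within the data shown here, this is the only number so far, as compound 1 and compound 2 have no reported result, so compound 3 cannot yet be ranked against anything.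

Compound 4 `Cc1ccc(S(=O)(=O)c2nc3ccccc3nc2Nc2cccc(N)c2)cc1` has the same atoms as compound 3, joined differently: 3-aminophenyl in place of 4-aminophenyl on a nitrogen on an aromatic ring. Here, 3-aminophenyl takes the place of 4-aminophenyl on a nitrogen on an aromatic ring. Among the measured compounds shown here, no measured pair shows what such a move does, so no step beyond the usual scatter is expected in this assay, and neither direction is favoured. The expected change is a 1.1-fold higher number from compound 3 to compound 4 (0.03 log units; within the scatter). The estimated value for compound 4 is 6000 nM, with an expected range of 2000 nM to 18000 nM.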

Compound 4, half-maximal inhibitory concentration: 10600 nM
For compound 4 the middle estimate is 1.8-fold (0.25 log units) below the measured one; measured number inside the range.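

Exchanging 4-aminophenyl for 3-aminophenyl on a nitrogen on an aromatic ring gives a 1.9-fold higher number from compound 3 to compound 4 (0.27 log units; within the scatter) in this assay. This first measured pair therefore shows that, in this one case, the exchange has no effect that can be told apart from ordinary variation between repeats. Nothing available bears on this result. Still open, as far as these compounds go, is whether a hydroxyl group or a carboxylic acid in place of the amine would change the number. Compound 1 and compound 2 also remain unplaced, having no reported result.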